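This account rests on a few compounds, and the source may have more. Where it says the series, first, only, none or still open, it means among the compounds named here.

Of the compounds shown here, two have been measured in an assay on Sf9 cells for inhibition of protein deacetylase HDAC6 (Homo sapiens), read by fluorescence, with a stated time of 40 min, tested at 100 nM; a higher number here means more inhibition at the concentration tested (going by the name of the read-out), a lower number less inhibition. Compound 1 `Cc1ccc(-c2nc(CNc3ccc(C(=O)NO)cc3)n(-c3ccccc3)n2)s1` gives 79.7%. Compound 2 `O=C(NO)c1ccc(NCc2nc(-c3ccccc3)nn2-c2ccccc2)cc1` gives 72.6% and so stands lowest of the two numbers shown, with compound 1 its only neighbour; between them lies a number 7.1 percentage points lower from compound 1 to compound 2 (within the scatter), a step that does not rise above the scatter. Compound 3 `O=C(NO)c1ccc(NCc2nc(-c3ccsc3)nn2-c2ccccc2)cc1` has no number yet in this assay. It differs from compound 2 in one place: thiophen-3-yl in place of phenyl on an aromatic carbon. For the measured compounds named here, only one measured step bears on this change, and it does so loosely, since it concerns a 5-methylthiophen-2-yl group rather than a thiophen-3-yl group, and it was within the scatter. Exchanging the phenyl on the shared core for a five-membered sulfur ring is therefore not expected to move the number in this assay beyond the scatter in either direction. The expected step is a number 2.4 percentage points higher from compound 2 to compound 3 (within the scatter). For compound 3 the estimate in this assay is 75%, with a range from 60% to 88%.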

Compound 3, a percentage reported as inhibition, at one concentration (the size of the read-out at that concentration, not a potency): 53.4%
Beside the measured number, compound 3's estimate is 21.6 percentage points above it, and the stated range ends above it.
By their numbers in this assay, from the lowest: compound 3; then compounds 2 and 1 (each within the scatter of the next).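

For the compounds shown here, on the aromatic carbon of the five-membered ring with 3 nitrogen, between two ring nitrogen atoms, the group is not interchangeable in this assay (a number 19.2 percentage points lower from compound 2 to compound 3 (beyond the scatter)) and this replacement of phenyl by thiophen-3-yl gives the first step that rises beyond the scatter, unlike the earlier exchange of 5-methylthiophen-2-yl for phenyl. The two sulfur-containing groups also part (a number 26.3 percentage points lower from compound 1 to compound 3 (beyond the scatter)) so a five-membered sulfur ring at this position does not by itself fix the read-out, and compound 3 stands apart from both neighbours while compounds 1 and 2 remain within the scatter of each other. No measurement among the data shown bears on the origin of this drop.

The compounds shown leave open whether the methyl group or the point of attachment on the thiophene separates compound 1 from compound 3, a question that an unsubstituted thiophen-2-yl group at the same carbon would address directly. Whether a furan-3-yl or pyridin-3-yl group would track phenyl or thiophen-3-yl also remains open, and a single tested concentration gives no potency for any of these compounds.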